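Removing One Methoxy Group from the Trimethoxyphenyl Side of Compound 2

The source may hold more compounds than are shown below. What is called first, only, known or untested is meant among the compounds shown, and "the series" means these compounds.

Compound 1 `COc1cc(/C=C2\CC/C(=C\c3ccc([N+](=O)[O-])cc3)C2=O)cc(OC)c1OC`: > 400000 nM (a limit)
Compound 2 `COc1cc(/C=C2\Cc3ccccc3/C(=C\c3ccc([N+](=O)[O-])cc3)C2=O)cc(OC)c1OC`: 3000 nM
Compound 3 `COc1cc(/C=C2/C(=O)/C(=C/c3ccc([N+](=O)[O-])cc3)c3ccccc32)cc(OC)c1OC`: > 400000 nM (a limit)

In a functional assay on HSG cells (Homo sapiens) for cytotoxicity (a lower number here means that less compound is tolerated, a higher number that more compound is tolerated), compound 2 gives 3000 nM and is the only one of the three with an actual number. For compound 1 this assay reports only a limit, > 400000 nM. For compound 3 it also reports only a limit, > 400000 nM. Going by the values given here, two of the three values therefore sit at the limit of > 400000 nM in this assay, at which 2 of the 3 values shown sit, so no measured pair differing in one place is available to scale a step.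

Compound 4 `COc1ccc(/C=C2\Cc3ccccc3/C(=C\c3ccc([N+](=O)[O-])cc3)C2=O)cc1OC` differs from compound 2 by hydrogen in place of methoxy on an aromatic carbon. A modest step toward more compound being tolerated is expected, a 2.0-fold higher number from compound 2 to compound 4 (0.30 log units; within the scatter), though a step within the scatter would not surprise. Compound 4 is expected to give 6000 nM, with a range from 1500 nM to 40000 nM.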

Compound 4, half-maximal cytotoxic concentration: 4400 nM
Beside the measured number, compound 4's estimate is 1.4-fold (0.13 log units) above it; the range from low to high includes it.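

In this assay, going by these compounds alone, replacing this methoxy with hydrogen gives a 1.5-fold higher number from compound 2 to compound 4 (0.17 log units; within the scatter), the first step in the set that can be read. At this place on the ring, ortho to a methoxy group, the methoxy can therefore give way to hydrogen without a change beyond the scatter. Steps to the other compounds cannot be read: the limit of > 400000 nM in this assay, at which 2 of the 4 values shown sit.

On these data alone, it remains open whether a hydroxyl, a fluorine or an amine at this position would behave like hydrogen. As far as these compounds go, it is also open whether the remaining methoxy groups can be replaced in the same way.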